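The source may report more compounds than this note shows. Statements on the series, on what has been measured and on what is new or still open speak of the compounds shown alone.

Measured so far in a functional assay on MCF7 cells (Homo sapiens) for inhibition; a higher number here means a weaker inhibitor, a lower number a stronger inhibitor:
compound 1, `O=C(CCC1CCCC1)N(O)c1ccc(Cl)cc1`, gives 10000 nM;
compound 2, `O=C(CC1CCCCC1)N(O)c1ccc(Cl)cc1`, gives 10000 nM;
compound 3, `O=C(CCC1CCCCC1)N(O)c1ccc(Cl)cc1`, gives 20000 nM.

Compound 2 stands level with compound 1 at the digits shown, and these two together hold the lowest of the three numbers; compound 3 sits furthest from compound 2. The two steps measured among these compounds both concern the saturated chain and the ring attached to it: one is no change at the digits printed from compound 1 to compound 2 (within the scatter), the other is a 2.0-fold higher number from compound 1 to compound 3 (0.30 log units; within the scatter). Both of these changes are within the scatter, so within this small set the chain and its ring can be altered without any clear movement in the number.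

Compound 4, `O=C(CC1CCCCC1)N(O)c1ccccc1`, differs from compound 2 in a single place: hydrogen in place of chloro on an aromatic carbon. Within the data shown here, none of the measured steps touches the aromatic ring or its chloro, so nothing measured bears directly on this change. With all three measured numbers close together and every measured step within the scatter, the expectation is a step of no change at the digits printed from compound 2 to compound 4 (within the scatter) that stays within the scatter, in no particular direction. Compound 4 is therefore expected to give 10000 nM in this assay, with a range from 4000 nM to 25000 nM.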

Compound 4, half-maximal inhibitory concentration: > 100000 nM
Compound 4: no number, only a limit (the forecaster's own chance of this, stated with the estimate: 20%); at least 10-fold (1.00 log units) between middle value and limit.
By their numbers in this assay, from the lowest: compounds 1, 2 and 3 (each within the scatter of the next). At a limit, above all of these: compound 4.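

In this assay compound 4 gives > 100000 nM, and this is a limit of the assay, not a number: the limit of > 100000 nM in this assay, at which 1 of the 4 values shown sits. Among these compounds, the chloro on the aromatic carbon, para to a large group, matters far more than the earlier compounds could suggest: putting hydrogen in its place gives an at least 10-fold higher number from compound 2 to compound 4 (1.00 log units; beyond the scatter), while the changes to the saturated chain and its ring all stayed within the scatter. Among the compounds shown here, of the places changed so far, this aromatic carbon is the only one where a single change moves the result beyond the scatter, so the chloro, and not the chain, is the feature that separates a measurable number from a limit here.

On these data alone, it remains open whether chlorine itself is required or whether another group in the same place, such as bromo, methyl or methoxy, would serve as well. As far as these compounds go, it is also open whether hydrogen in place of chloro would have a similar effect on the cyclopentyl chain of compound 1 or the longer cyclohexyl chain of compound 3.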